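The source may report more compounds than this note shows. Statements on the series, on what has been measured and on what is new or still open speak of the compounds shown alone.

In an ADME assay on a cell-free system (plasma, Homo sapiens) for metabolic stability, tested at 1 uM (on this read-out higher numbers stand for a longer-lived compound and lower numbers for a shorter-lived compound), two compounds built on a shared core have been measured so far: compound 1 (`C=CC(=O)NC1CCN(S(=O)(=O)c2ccc(C(=O)NCCCc3ccccc3)cc2)CC1`) and compound 2 (`C=CC(=O)NC1CCN(S(=O)(=O)c2ccc(C(=O)NCCC3CCCCC3)cc2)CC1`). Compound 1 reads > 6 h, which is a limit of the assay and not a number. Compound 2 reads > 6 h, which is likewise a limit. The two therefore stand together, and the record is brief: the limit of > 6 h in this assay, at which 2 of the 2 values shown sit. The next compound is compound 3 (`C=CC(=O)NC1CCN(S(=O)(=O)c2ccc(C(=O)NCc3cccc4ccccc34)cc2)CC1`), which carries naphthalen-1-yl in place of cyclohexylmethyl on a saturated chain carbon bound to an amide-type nitrogen. Within the data shown here, the only measured step bearing on this change is a step that the two limits leave unreadable from compound 1 to compound 2, so it offers no size to carry over, and no step beyond the scatter is expected in this assay. The expected step is a step that the limit leaves unreadable from compound 2 to compound 3. For compound 3 the estimate is 8 h, with an expected range from 4 h to 16 h.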

Compound 3, half-life: > 6 h
Compound 3: a limit, no number (the forecaster's own chance of this, stated with the estimate: 80%); the middle value is on the limit's open side.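

In this assay compound 3 gives > 6 h as a limit and not a number. Among these compounds, no step among compound 1, compound 2 and compound 3 can be read: the limit of > 6 h in this assay, at which 3 of the 3 values shown sit. The compounds shown leave open what half-life any of the three really has, and whether exchanging these groups changes it at all.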